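The source may report more compounds than this note shows. Statements on the series, on what has been measured and on what is new or still open speak of the compounds shown alone.

Measured in an ADME assay on RAW264.7 cells (Mus musculus) for cytotoxicity, read by MTT assay, with a stated time of 72 h, tested at 50 uM; a higher number here means more inhibition at the concentration tested (going by the name of the read-out), a lower number less inhibition:

compound 1 `CCOC(=O)c1sc(-c2ccccn2)nc1N1CCC(NCc2ccc(OC)cc2)CC1`: 4.62%
compound 2 `CCOC(=O)c1sc(-c2ccncc2)nc1N1CCC(NCc2ccc(OC)cc2)CC1`: 16.1%
compound 3 `CCOC(=O)c1sc(-c2ccncc2)nc1N1CCC(NCc2ccc(OCc3ccccc3)cc2)CC1`: 8.04%

Compound 2 holds the highest of the three numbers. Its nearest neighbour is compound 3, and that gap a number 8.1 percentage points lower from compound 2 to compound 3 (within the scatter) lies within the scatter, so the two cannot be ordered; the gap to compound 1, a number 11.5 percentage points higher from compound 1 to compound 2 (beyond the scatter), is beyond the scatter and counts as a modest step.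

Compound 4 `CCOC(=O)c1sc(-c2ccncc2)nc1N1CCC(NCc2ccc(Cl)cc2Cl)CC1` is not yet measured. It differs from compound 2 as follows:

2,4-dichlorophenyl in place of 4-methoxyphenyl on a saturated chain carbon bound to an amine nitrogen

Among the compounds with values here, of the measured steps, the one from compound 2 to compound 3 is the closer analogue, as it also alters the group on the saturated chain carbon bound to the amine nitrogen, and it came out within the scatter. The step from compound 1 to compound 2 changes a different part of the molecule and bears only loosely on this case. Within the data shown here, no measured pair swaps the 4-methoxyphenyl for a halogenated ring, so the direction is not fixed by the data.

The expectation for this assay is therefore a step from compound 2 to compound 4 of a number 0.1 percentage points lower from compound 2 to compound 4 (within the scatter), not beyond the scatter. Compound 4 is estimated at 16%, with a range from 5% to 30%.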

Compound 4, a percentage reported as inhibition, at one concentration (the size of the read-out at that concentration, not a potency): 18.4%
Compound 4: the middle estimate sits 2.4 percentage points below what was measured; low and high end bracket the measured number.
By their numbers in this assay, from the lowest: compounds 1, 3, 2 and 4 (each within the scatter of the next, the first and the last beyond it).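

In this assay the swap of 4-methoxyphenyl for 2,4-dichlorophenyl on a saturated chain carbon bound to an amine nitrogen gives a number 2.3 percentage points higher from compound 2 to compound 4 (within the scatter) and so leaves the two compounds unordered. This step exchanges the whole ring substituent pattern, with the oxygen and its hydrogen-bond acceptor leaving and two chlorines entering, whereas the earlier change at this end of the molecule, a number 8.1 percentage points lower from compound 2 to compound 3 (within the scatter), only put phenyl in place of hydrogen on the carbon bound to the ring oxygen; at this position, then, neither the larger group on that oxygen nor the loss of the methoxy group in favour of two chlorines produces a step beyond the scatter. No other measurement bears on this result, and nothing here accounts for it.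

As far as these compounds go, whether an amine or a carboxylic acid on this ring, or a longer chain in place of the benzyl link to the amine nitrogen, would give a step beyond the scatter stays open. Also open, from the compounds shown here alone, is whether the 2,4-dichlorobenzyl group would give a comparable number with pyridin-2-yl in place of pyridin-4-yl on the shared core.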